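Larger fluorinated group on the ring-nitrogen aryl

The source may report more compounds than this note shows. Statements on the series, on what has been measured and on what is new or still open speak of the compounds shown alone.

Three compounds have been measured in a functional assay on 143B cells (Homo sapiens) for inhibition, read by CCK-8 assay, with a stated time of 72 h, tested at 1 uM; on this read-out lower numbers stand for less inhibition and higher numbers for more inhibition at the one concentration tested (going by the name of the read-out):
compound 1, `COc1ccc(OC)c(N2C(=O)CSC2c2cccc(C(=O)NCCCCc3ccccc3)c2)c1`, gives 2%
compound 2, `O=C(NCCCCc1ccccc1)c1cccc(C2SCC(=O)N2c2ccccc2)c1`, gives 60%
compound 3, `O=C(NCCCCc1ccccc1)c1cccc(C2SCC(=O)N2c2cccc(F)c2)c1`, gives 63%

Compound 3 stands highest of the three numbers. Its nearest neighbour is compound 2, with a number 3 percentage points higher from compound 2 to compound 3 (within the scatter), a gap within the scatter, so no order between these two can be claimed. Its furthest is compound 1, with a number 61 percentage points higher from compound 1 to compound 3 (beyond the scatter).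

Compound 4, `CC(F)(F)c1cccc(N2C(=O)CSC2c2cccc(C(=O)NCCCCc3ccccc3)c2)c1`, has not been measured. It differs from compound 3 in one place: 1,1-difluoroethyl in place of fluoro on an aromatic carbon. For the measured compounds named here, the only measured step at that same aromatic carbon is a number 3 percentage points higher from compound 2 to compound 3 (within the scatter), which was within the scatter. The large steps of a number 58 percentage points higher from compound 1 to compound 2 (beyond the scatter) and a number 61 percentage points higher from compound 1 to compound 3 (beyond the scatter) concern a change on the amide-type nitrogen in a ring and do not bear on this one. Going by the values given here, no measured step tells how a group of four heavy atoms at that carbon behaves, so the expectation rests on the single small step there. The expected step is a number 8 percentage points lower from compound 3 to compound 4 (within the scatter), with wide uncertainty. Compound 4 is estimated at 55%, within a range from 30% to 75%.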

Compound 4, a percentage reported as inhibition, at one concentration (the size of the read-out at that concentration, not a potency): 1%
Compound 4: middle estimate off by 54 percentage points, on the high side; the whole stated range lies above it.
By their numbers in this assay, from the lowest: compounds 4 and 1 (each within the scatter of the next); then compounds 2 and 3 (each within the scatter of the next).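

In this assay, for the compounds shown here, the earlier compounds showed only that fluoro and hydrogen on this aromatic carbon cannot be told apart, whereas 1,1-difluoroethyl shows that the position does respond to what sits there, with a number 62 percentage points lower from compound 3 to compound 4 (beyond the scatter) and a number 59 percentage points lower from compound 2 to compound 4 (beyond the scatter). This one change on the ring-nitrogen aryl removes nearly all of the read-out, and the result matches that of the 2,5-dimethoxyphenyl group, with a number 1 percentage points lower from compound 1 to compound 4 (within the scatter), so no order between those two compounds can be claimed. Nothing available here explains why the number falls.

As far as these compounds go, it remains open whether every group larger than fluoro fails on this carbon or only 1,1-difluoroethyl does, which methyl, methoxy or an amine there could begin to settle. From the compounds shown here alone, it is also open whether 1,1-difluoroethyl would give the same result on another carbon of this ring.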